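The compounds below may be only part of what the source reports. "The series", "measured", "known", "first", "only" and "open" are said of these compounds alone.

Measured so far: compound 1 `CC1CCN(C2CCN(S(=O)(=O)c3cccc(C(F)(F)F)c3)CC2)CC1`, compound 2 `Cc1ccc(C2CCN(S(=O)(=O)c3c(C)cc(C)cc3C)CC2)cc1`, compound 3 `Cc1cc(C)c(S(=O)(=O)N2CCC(N3CCN(C)CC3)CC2)c(C)c1`.

In a functional assay on DLD-1 cells (Homo sapiens) for antiproliferative activity, read by CellTiter-Glo, with a stated time of 72 h (on this read-out higher numbers stand for weaker inhibition and lower numbers for stronger inhibition), compound 1 gives only a limit, > 5000 nM; this is the limit of > 5000 nM in this assay, at which 1 of the 3 values shown sits. Compound 2 gives 2200 nM. Compound 3 gives 1100 nM. Among the measured compounds shown here, the one counted step, a 2.0-fold lower number from compound 2 to compound 3 (0.30 log units; within the scatter), concerns the saturated ring carbon and not the aromatic sulfonyl ring.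

Compound 4 `CC1CCN(C2CCN(S(=O)(=O)c3cccc(Cl)c3)CC2)CC1` differs from compound 1 by chloro in place of trifluoromethyl on an aromatic carbon. For the measured compounds named here, no measured step touches a change on this aromatic ring, so no shift beyond the scatter is expected in either direction. Compound 1 stands at the limit of the assay, and nothing measured points away from it. The estimate for compound 4 is 5000 nM, with a range from 2000 nM to 15000 nM. The expected step is a number no higher from compound 1 to compound 4 (the limit leaves the size open), within the scatter, and a limit rather than a number is the likelier outcome.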

Compound 4, half-maximal inhibitory concentration: > 5000 nM
Compound 4: no number, only a limit (the forecaster's own chance of this, stated with the estimate: 65%); the middle value lies on the limit itself.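

Among the compounds shown here, compound 1 and compound 4 each give only a limit, so no step between them can be read: the limit of > 5000 nM in this assay, at which 2 of the 4 values shown sit.

The compounds shown leave open how chloro and trifluoromethyl compare on this aromatic carbon.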